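Fused heteroaryl swap in a series without measurable inhibition

This account rests on a few compounds, and the source may have more. Where it says the series, first, only, none or still open, it means among the compounds named here.

Compound 1 `Nc1cc(-c2cc(Cl)cc3c2OC(C(=O)N2CCNCC2)C3)ccn1` carries a 2-aminopyridin-4-yl group on the shared core. In an assay on Sf21 cells for inhibition of ubiquitin carboxyl-terminal hydrolase 1 (Homo sapiens), read by fluorescence (on this read-out higher numbers stand for weaker inhibition and lower numbers for stronger inhibition), compound 1 gives only a limit, > 80000 nM. Compound 2 `O=C([C@H]1Cc2cc(Cl)cc(-c3ccnc4ccsc34)c2O1)N1CCNCC1` carries a different fused heteroaryl group; in this assay compound 2 gives a limit, > 40000 nM. Compound 3 `O=C([C@H]1Cc2cc(Cl)cc(-c3ccnc4cc(CO)sc34)c2O1)N1CCNCC1` adds a hydroxymethyl on an aromatic carbon of that group; in this assay compound 3 gives a limit as well, > 40000 nM. The step that the two limits leave unreadable from compound 2 to compound 3 is therefore unreadable. Compound 1 thus stands at a limit, and the other two values shown are limits too, resting on the limit of > 40000 nM in this assay, at which 2 of the 3 values shown sit, and (the limit of > 80000 nM in this assay, at which 1 of the 3 values shown sits).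

Compound 4 `O=C(C1Cc2cc(Cl)cc(-c3ccnc4[nH]ccc34)c2O1)N1CCNCC1` differs from compound 1 by a group of 9 heavy atoms (7 carbon, 2 nitrogen; one five-membered aromatic ring with 1 hetero atom, one six-membered aromatic ring with 1 hetero atom) in place of a group of 7 heavy atoms (5 carbon, 2 nitrogen; one six-membered aromatic ring with 1 hetero atom), on an aromatic carbon. No measured step bears on this change, since the single step shown is unreadable and no compound in the series reaches a number. With every value a limit, the step from compound 1 to compound 4 is expected to stay unreadable, an at least 1.3-fold lower number from compound 1 to compound 4 (0.12 log units; that floor lies within the scatter). Compound 4 is expected at 60000 nM, within 15000 nM to 200000 nM, most likely reported again only as a limit.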

Compound 4, half-maximal inhibitory concentration: > 80000 nM
Compound 4: a limit, no number; the forecaster's own chance of this, stated with the estimate: 80%; middle value at least 1.3-fold (0.12 log units) away from the limit.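

In this assay compound 4 gives > 80000 nM, a limit and not a number. Compound 1 is also a limit, so the step from compound 1 to compound 4 cannot be read. Left open is how strongly any compound shown inhibits, as all four values are limits.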